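The source may report more compounds than this note shows. Statements on the series, on what has been measured and on what is new or still open speak of the compounds shown alone.

Compound 1 `CC(C)=CCCC1=CC[C@H](C(=O)NO)[C@@H](c2ccccc2)C1` carries a hydroxy group on the amide-type nitrogen of the shared core, and in an assay on isolated protein for inhibition of Apoptosis regulator Bcl-2 (Homo sapiens), read by fluorescence polarization, with stated times of 5 min and 10 min (a lower number here means a stronger inhibitor, a higher number a weaker inhibitor), compound 1 gives 600 nM, the lowest of the three numbers in hand. Compound 2 `CONC(=O)[C@@H]1CC=C(CCC=C(C)C)C[C@H]1c1ccccc1`, with a methoxy group in that position, gives 2700 nM in this assay, and compound 3 `COC(=O)CCNC(=O)[C@H]1CC=C(CCC=C(C)C)C[C@@H]1c1ccccc1` gives 3100 nM. Among the compounds with values here, the only step between measured compounds that differ in a single place is a 5.2-fold higher number from compound 1 to compound 3 (0.71 log units; beyond the scatter), with 2-(methoxycarbonyl)ethyl in place of hydroxy on an amide-type nitrogen. Compound 4 `CC(C)=CCCC1=CC[C@H](C(=O)Nc2ccc(C(=O)O)cc2)[C@@H](c2ccccc2)C1` has not yet been measured in this assay. Against compound 1 it shows this difference: 4-carboxyphenyl in place of hydroxy on an amide-type nitrogen. Within the data shown here, the step that bears on it is the one from compound 1 to compound 3, which was modest but beyond the scatter, and the numbers for compound 1 and compound 2 point the same way. Compound 4 is therefore expected to come out a weaker inhibitor than compound 1, by a step of about a 4.2-fold higher number from compound 1 to compound 4 (0.62 log units; beyond the scatter). For compound 4 the estimated value in this assay is 2500 nM, with a likely range from 800 nM to 8000 nM.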

Compound 4, inhibition constant: > 23000 nM
Compound 4: no number, only a limit; the forecaster's own chance of this, stated with the estimate: 10%; middle value at least 9.2-fold (0.96 log units) away from the limit.
By their numbers in this assay, from the lowest: compound 1; then compounds 2 and 3 (each within the scatter of the next). At a limit, above all of these: compound 4.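

In this assay, the reading for compound 4 is a limit and not a number: the limit of > 23000 nM in this assay, at which 1 of the 4 values shown sits. At the amide-type nitrogen of the shared core, 4-carboxyphenyl in place of hydroxy gives an at least 38-fold higher number from compound 1 to compound 4 (1.58 log units; beyond the scatter), and 4-carboxyphenyl in place of 2-(methoxycarbonyl)ethyl gives an at least 7.4-fold higher number from compound 3 to compound 4 (0.87 log units; beyond the scatter). Within the data shown here, the earlier compounds showed only that this nitrogen tolerates hydroxy, methoxy and 2-(methoxycarbonyl)ethyl with measurable numbers and a modest step, whereas this result shows that the choice of group here can cost far more than that step, with 4-carboxyphenyl the only group of the four that yields a limit.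

The compounds shown leave open whether the large step goes with the six-membered aromatic ring or with the carboxylic acid, as 4-carboxyphenyl brings in both at once. A plain phenyl on that nitrogen, or a carboxylic acid carried on an open chain such as 2-carboxyethyl, would separate the two.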